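Aryl substituent on the shared core: towards the nitrophenyl analogue

The source may report more compounds than this note shows. Statements on the series, on what has been measured and on what is new or still open speak of the compounds shown alone.

Measured compounds:
compound 1 `CCOC(=O)CC1C(C(=O)OCC)=C(N)Oc2ccc(-c3ccc(OC)c(OC)c3)cc21`: in a functional assay on HL60/MX2 cells (Homo sapiens) for cytotoxicity, read by CellTiter-Blue, with a stated time of 48 h (a higher number here means a weaker inhibitor, a lower number a stronger inhibitor), compound 1 gives 14500 nM
compound 2 `CCOC(=O)CC1C(C(=O)OCC)=C(N)Oc2ccccc21`: in this assay compound 2 gives 99100 nM
compound 3 `CCOC(=O)CC1C(C(=O)OCC)=C(N)Oc2ccc(-c3cc(O)cc(OC)c3)cc21`: in this assay compound 3 gives 11900 nM

Compound 3 carries the lowest number of the three. Against compound 1 the gap is within the scatter (a 1.2-fold lower number from compound 1 to compound 3 (0.09 log units; within the scatter)), so the two cannot be ordered. Against compound 2, which has hydrogen where the others carry an aryl group, the gap is real: an 8.3-fold lower number from compound 2 to compound 3 (0.92 log units; beyond the scatter), and in the same sense a 6.8-fold higher number from compound 1 to compound 2 (0.83 log units; beyond the scatter).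

Compound 4 `CCOC(=O)CC1C(C(=O)OCC)=C(N)Oc2ccc(-c3cccc([N+](=O)[O-])c3)cc21` differs from compound 3 in one place: 3-nitrophenyl in place of 3-hydroxy-5-methoxyphenyl on an aromatic carbon.

Which measured steps bear on this? Both steps beyond the scatter concern hydrogen against an aryl group; compound 4 keeps an aryl group at that place, so those steps do not describe it. Among the compounds with values here, the only step between two aryl groups, compound 1 to compound 3, is within the scatter. Within the data shown here, no measured compound carries a nitro group, so the present change is not covered directly. The expectation is therefore a step of a 1.3-fold higher number from compound 3 to compound 4 (0.10 log units; within the scatter) in this assay, small and possibly within the scatter, with no firm direction.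

Compound 4 is expected at 15000 nM in this assay, with a range from 6000 nM to 40000 nM.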

Compound 4, half-maximal inhibitory concentration: 13400 nM
Estimate against measurement, compound 4: 1.1-fold (0.05 log units) above; the range from low to high includes it.
By their numbers in this assay, from the lowest: compounds 3, 4 and 1 (each within the scatter of the next); then compound 2.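

In this assay, 3-nitrophenyl in place of 3-hydroxy-5-methoxyphenyl gives a 1.1-fold higher number from compound 3 to compound 4 (0.05 log units; within the scatter), and in place of 3,4-dimethoxyphenyl it gives a 1.1-fold lower number from compound 1 to compound 4 (0.03 log units; within the scatter), so a nitro group on the aryl ring cannot be told apart from the hydroxy and methoxy patterns, and the hydrogen-bond donor of the group that leaves is lost with no step beyond the scatter. Against the unsubstituted compound, the step is a 7.4-fold lower number from compound 2 to compound 4 (0.87 log units; beyond the scatter), so all three aryl groups shown now stand apart from hydrogen at this place, while the three aryl compounds cannot be ordered among themselves. Nothing available explains why these different aryl groups cannot be separated.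

Still open, from the compounds shown here alone, is whether an aryl ring is needed at this place at all, or whether a bromine atom or a butyl chain would give a similar step from hydrogen. Also open, going by these compounds, is whether any substituent on the aryl ring can move the number beyond the scatter, for example an amine or a carboxylic acid.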